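Swapping methoxy for chloro on a shared core

A few compounds are considered here, and "the series" means these few. Any claim that something is new, unique, unknown or untested is made for them only; others in the source may bear on it.

Of the compounds shown here, three built on one shared core have been measured in an assay on membranes from brain for displacement of a labelled ligand from adenosine receptor A1 (Rattus norvegicus); on this read-out higher numbers stand for weaker inhibition and lower numbers for stronger inhibition. Compound 3 `COc1ccc(-c2nc3ccccn3c2NC2CCCCC2)cc1` gives 7610 nM, the higher of the two numbers. Compound 1 `Brc1ccc(-c2nc3ccccn3c2NC2CCCCC2)cc1` gives 3900 nM, and the step of a 2.0-fold higher number from compound 1 to compound 3 (0.29 log units; within the scatter) lies within the scatter. Compound 2 `Fc1ccc(-c2nc3ccccn3c2NC2CCCCC2)cc1` reaches only the limit of > 100000 nM. From compound 3 to compound 4 `Clc1ccc(-c2nc3ccccn3c2NC2CCCCC2)cc1` the change is chloro in place of methoxy on an aromatic carbon. Among the measured compounds shown here, two measured steps bear on it: methoxy in place of bromo gave a 2.0-fold higher number from compound 1 to compound 3 (0.29 log units; within the scatter), while fluoro in place of bromo gave an at least 25-fold higher number from compound 1 to compound 2 (1.40 log units; beyond the scatter), recorded as the limit of > 100000 nM in this assay, at which 1 of the 3 values shown sits. In this assay the expected step is a 1.5-fold lower number from compound 3 to compound 4 (0.18 log units; within the scatter), within the scatter. Compound 4 is thus estimated at 5000 nM in this assay, with a range of 1500 nM to 30000 nM.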

Compound 4, inhibition constant: > 100000 nM
Compound 4: a limit, no number; the forecaster's own chance of this, stated with the estimate: 10%; middle value at least 20-fold (1.30 log units) from the limit.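

In this assay, compound 4 gives a limit and no number, and it joins compound 2 there: the limit of > 100000 nM in this assay, at which 2 of the 4 values shown sit. Chloro in place of methoxy gives an at least 13-fold higher number from compound 3 to compound 4 (1.11 log units; beyond the scatter), and chloro in place of bromo gives an at least 25-fold higher number from compound 1 to compound 4 (1.40 log units; beyond the scatter), so at this position swapping one halogen for another can be a large change, and among the halogens shown only bromo keeps a readable number. The step between compound 2 and compound 4 cannot be read, as both values are limits.

Going by these compounds, whether iodo, an amine or a carboxylic acid at this position would give a readable number stays open. So does how far compound 2 and compound 4 lie past the limit.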